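Iodine Enters the Amide Ring: From Compound 2 to Compound 3

The compounds below may be only part of what the source reports. "The series", "measured", "known", "first", "only" and "open" are said of these compounds alone.

Of the compounds shown here, two built on the same core have been measured. Compound 1 `NC(=O)c1c(NC(=O)c2ccccc2Cl)sc2c1CCN(Cc1ccc(Cl)cc1Cl)C2` in a functional assay on HL-60 cells (Homo sapiens) for antiproliferative activity, with a stated time of 24 h (a higher number here means a weaker inhibitor, a lower number a stronger inhibitor), gives 8010 nM. Compound 2 `NC(=O)c1c(NC(=O)c2ccccc2)sc2c1CCN(C(=S)Nc1ccccc1Cl)C2` differs from it at two places and in this assay gives 13800 nM. That is the higher of the two numbers, but the gap to compound 1 lies within the usual scatter, so the two cannot be ranked against each other. Compound 3 `NC(=O)c1c(NC(=O)c2ccccc2I)sc2c1CCN(C(=S)Nc1ccccc1Cl)C2` differs from compound 2 in one place only: iodo in place of hydrogen on an aromatic carbon. Among the compounds with values here, no measured pair shows this exact change, so its effect is unknown from direct evidence. Within the data shown here, since the one change is small and the nearest comparison, compound 1, differs elsewhere as well, the expected step of a 1.5-fold lower number from compound 2 to compound 3 (0.19 log units; within the scatter) is modest, probably no larger than the scatter, with a slight lean toward a lower number. Compound 3 is therefore estimated at 9000 nM, within a range from 3000 nM to 27000 nM.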

Compound 3, half-maximal inhibitory concentration: 8560 nM
Estimate against measurement, compound 3: 1.1-fold (0.02 log units) above; measured number inside the range.
By their numbers in this assay, from the lowest: compounds 1, 3 and 2 (each within the scatter of the next).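

In this assay, within the data shown here, replacing hydrogen with iodo on the benzamido phenyl ring gives a 1.6-fold lower number from compound 2 to compound 3 (0.21 log units; within the scatter), the first reading of a change made at a single place on this core. At this carbon, ortho to a large group, adding this one heavy atom therefore has no effect that can be told apart from ordinary repeat-to-repeat variation, and compound 2 and compound 3 cannot be ranked against each other. Nothing available here offers an explanation for this result.

As far as these compounds go, it remains open whether a different group on this same carbon, such as a methoxy, an amine or a carboxylic acid, would give a step beyond the scatter. Also open, from the compounds shown here alone, is whether iodo on another carbon of this ring would behave the same way.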